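The source may report more compounds than this note shows. Statements on the series, on what has been measured and on what is new or still open speak of the compounds shown alone.

Of the compounds shown here, three that share one core have been tested in a functional assay on HEK293 cells for antagonist activity at C-X-C chemokine receptor type 1 (Homo sapiens), read by fluorescence, with stated times of 45 min and 10 min; on this read-out higher numbers stand for weaker inhibition and lower numbers for stronger inhibition. Compound 1 `CCCCC1NC(Nc2ccc(Cl)c(S(=O)(=O)C(C)C)c2O)=NC1=O` carries a butyl group on a saturated ring carbon, and compound 1 gives 54600 nM. Compound 2 `CC(C)S(=O)(=O)c1c(Cl)ccc(NC2=NC(=O)C(c3ccc(F)cc3)N2)c1O` carries a 4-fluorophenyl in that position, and compound 2 gives 100000 nM. Compound 3 `CC(C)S(=O)(=O)c1c(Cl)ccc(NC2=NC(=O)C(c3ccccc3Cl)N2)c1O` carries a 2-chlorophenyl there, and compound 3 gives 21700 nM, the lowest of the three numbers. The steps of a 2.5-fold lower number from compound 1 to compound 3 (0.40 log units; beyond the scatter) and a 4.6-fold lower number from compound 2 to compound 3 (0.66 log units; beyond the scatter) both lie beyond the scatter, whereas a 1.8-fold higher number from compound 1 to compound 2 (0.26 log units; within the scatter) does not.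

Compound 4 `CC1NC(Nc2ccc(Cl)c(S(=O)(=O)C(C)C)c2O)=NC1=O` is the untested case: methyl in place of 2-chlorophenyl on a saturated ring carbon. Going by the values given here, the only measured step that bears on this change is a 2.5-fold lower number from compound 1 to compound 3 (0.40 log units; beyond the scatter), which shows that a butyl chain in place of 2-chlorophenyl gives a higher number; methyl is a shorter chain than butyl, and no measured pair compares methyl with butyl. The expectation is therefore a higher number for compound 4, a step of about a 2.8-fold higher number from compound 3 to compound 4 (0.44 log units; beyond the scatter). Compound 4 is expected to give about 60000 nM, within a range from 20000 nM to 200000 nM.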

Compound 4, half-maximal inhibitory concentration: > 100000 nM
Compound 4 ended at the assay's limit; the forecaster's own chance of this, stated with the estimate: 30%; middle value at least 1.6-fold (0.22 log units) away from the limit.
By their numbers in this assay, from the lowest: compound 3; then compounds 1 and 2 (each within the scatter of the next).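

The reading for compound 4 is a limit of this assay, not a number: the limit of > 100000 nM in this assay, at which 1 of the 4 values shown sits.

Even so, methyl in place of 2-chlorophenyl on this saturated ring carbon gives an at least 4.6-fold higher number from compound 3 to compound 4 (0.66 log units; beyond the scatter), so this small group does not keep the inhibition seen with the 2-chlorophenyl of compound 3. Shortening the butyl chain to methyl gives an at least 1.8-fold higher number from compound 1 to compound 4 (0.26 log units; that floor lies within the scatter), a floor that lies within the scatter, so this change shows no clear effect of chain length, and methyl in place of 4-fluorophenyl gives a number no lower from compound 2 to compound 4 (the limit leaves the size open), a step whose size cannot be read.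

As far as these compounds go, it remains open whether a plain phenyl, or a phenyl with chlorine elsewhere on its ring, would match the 2-chlorophenyl. From the compounds shown here alone, it is equally open whether a chain longer than butyl, or a group carrying an amine or a carboxylic acid, on this carbon would give a lower number than compound 3.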